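2,4-Difluorophenyl in place of 2-methoxyphenyl: working notes

This account rests on a few compounds, and the source may have more. Where it says the series, first, only, none or still open, it means among the compounds named here.

In a functional assay on MGC-803 cells (Homo sapiens) for cytotoxicity, read by MTT assay, with a stated time of 72 h (a higher number here means a weaker inhibitor, a lower number a stronger inhibitor), compound 1 `COc1cccc(C=C2C(=O)N(c3ccc(Cl)cc3)N(c3ccc(Cl)cc3)C2=O)c1OC` gives 29600 nM and compound 2 `COc1ccccc1C=C1C(=O)N(c2ccc(Cl)cc2)N(c2ccc(Cl)cc2)C1=O` gives 28600 nM with the two values within the scatter of each other. Among the measured compounds shown here, compound 2 therefore stands level with the only other measured compound. Compound 3 `O=C1C(=Cc2ccc(F)cc2F)C(=O)N(c2ccc(Cl)cc2)N1c1ccc(Cl)cc1` carries 2,4-difluorophenyl in place of 2-methoxyphenyl on a double-bonded chain carbon bound to a double-bonded ring carbon. For the measured compounds named here, the one measured step that bears on this change is a 1.0-fold lower number from compound 1 to compound 2 (0.01 log units; within the scatter) and it lies within the scatter, with hydrogen in place of methoxy on an aromatic carbon. Going by the values given here, no measured compound carries 2,4-difluorophenyl, so that step offers limited guidance and the range stays wide. The estimated step is a 1.2-fold lower number from compound 2 to compound 3 (0.08 log units; within the scatter) and no change beyond the scatter is expected in this assay in either direction. The estimate for compound 3 is an expected 24000 nM (estimated range 10000 nM to 50000 nM).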

Compound 3, half-maximal inhibitory concentration: 35700 nM
Compound 3: the middle estimate sits 1.5-fold (0.17 log units) below what was measured, and the stated range covers the measured number.
By their numbers in this assay, from the lowest: compounds 2, 1 and 3 (each within the scatter of the next).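

In this assay, 2,4-difluorophenyl in place of 2-methoxyphenyl on a double-bonded chain carbon bound to a double-bonded ring carbon gives a 1.2-fold higher number from compound 2 to compound 3 (0.10 log units; within the scatter) and, in place of 2,3-dimethoxyphenyl at the same carbon, a 1.2-fold higher number from compound 1 to compound 3 (0.08 log units; within the scatter). The earlier pair varied only the number of methoxy groups on this ring, whereas compound 3 has none and carries fluorine instead, and all three compounds still stand level. No data at hand speak to what lies behind these numbers.

Whether any group at this place can move the number beyond the scatter remains open, as all three substituted phenyl groups shown give level values. A phenyl ring bearing a dimethylamino group or a carboxylic acid, or a longer chain at this carbon, would test that question.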